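This account rests on a few compounds, and the source may have more. Where it says the series, first, only, none or still open, it means among the compounds named here.

Going by the values given here, in a functional assay on HCT-116 cells (Homo sapiens) for inhibition, read by colorimetric assay, with a stated time of 3 days (a lower number here means a stronger inhibitor, a higher number a weaker inhibitor), compound 1 `O=C(CCCCCCNC(=O)C(O)(O)C(F)(F)F)Nc1ccncc1` gives 6670 nM and stands highest of the two numbers so far. Compound 2 `COc1ccc2sc(NC(=O)CCCCCCNC(=O)C(O)(O)C(F)(F)F)nc2c1` reads lower at 2180 nM and that gap lies beyond the scatter. Compound 3 `CC(=O)c1ccc(NC(=O)CCCCCCNC(=O)C(O)(O)C(F)(F)F)cc1` carries 4-acetylphenyl in place of pyridin-4-yl on an amide-type nitrogen and keeps the rest of compound 1. Among the compounds with values here, no measured step covers this change. Within the data shown here, with compound 2 at 2180 nM as the only other reading, a small move to a lower number in this assay is expected, probably not beyond the scatter. The estimated 1.9-fold lower number from compound 1 to compound 3 (0.28 log units; within the scatter) is small and points downward. Compound 3 is estimated at 3500 nM with an expected range from 1300 nM to 8000 nM for now.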

Compound 3, half-maximal inhibitory concentration: 12100 nM
Compound 3: the middle estimate sits 3.5-fold (0.54 log units) below what was measured, outside the stated range (above it).
By their numbers in this assay, from the lowest: compound 2; then compounds 1 and 3 (each within the scatter of the next).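

On the amide-type nitrogen, 4-acetylphenyl in place of pyridin-4-yl gives a 1.8-fold higher number from compound 1 to compound 3 (0.26 log units; within the scatter) in this assay. This position therefore accepts a carbon-only aromatic ring with an acetyl group in place of a ring with a hetero atom, with no change beyond the scatter. No measured evidence bears on this result.

The two changes within this step remain unseparated, and a plain phenyl on the same nitrogen would divide them. The compounds shown also leave open how a shorter or longer chain would read.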